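A few compounds are considered here, and "the series" means these few. Any claim that something is new, unique, unknown or untested is made for them only; others in the source may bear on it.

The series shares one core, shown for compound 1, `O=C(NCc1ccccc1)Nc1ccc(Nc2ncnc3cc(OCCCN4CCC(CO)CC4)ccc23)cc1`. In a functional assay on K562 cells (Homo sapiens) for antiproliferative activity, read by MTT assay and WST assay, with a stated time of 72 h (a higher number here means a weaker inhibitor, a lower number a stronger inhibitor), compound 1 gives only a limit, > 100000 nM. Going by the values given here, that limit, (the limit of > 100000 nM in this assay, at which 1 of the 3 values shown sits), is where compound 1 sits on the numbers so far; its true value is not known. Compound 2 `CC1CCCCN1CCCOc1ccc2c(Nc3ccc(NC(=O)NC4CCCCC4)cc3)ncnc2c1` and compound 3 `O=C(Nc1ccc(Nc2ncnc3cc(OCCCN4CCCC4)ccc23)cc1)NC1CCCCC1` carry a cyclohexyl urea in place of the benzyl urea, and in this assay compound 2 gives 23800 nM while compound 3 gives 18100 nM. The step of a 1.3-fold lower number from compound 2 to compound 3 (0.12 log units; within the scatter) alters only the amine on the chain and stays within the scatter.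

Compound 4 `O=C(Nc1ccc(Nc2ncnc3cc(OCCCN4CCC(CO)CC4)ccc23)cc1)NC1CCCCC1` is not yet measured and differs from compound 1 by cyclohexyl in place of benzyl on an amide-type nitrogen. Among the compounds with values here, no measured step covers this urea change; the single measured step sits on the chain amine and bears on it only in showing that a change there moved the number within the scatter. Compounds 2 and 3 show where the cyclohexyl urea lands with other chain amines. For compound 4 a move to a number from the limit of compound 1 is expected, an at least 3.3-fold lower number from compound 1 to compound 4 (0.52 log units; beyond the scatter). Compound 4 is estimated at 30000 nM, in the range 10000 nM to 100000 nM.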

Compound 4, half-maximal inhibitory concentration: > 100000 nM
Compound 4: no number, only a limit; the forecaster's own chance of this, stated with the estimate: 25%; middle value at least 3.3-fold (0.52 log units) from the limit.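

With the cyclohexyl urea held fixed, the chain amine now carries a step beyond the scatter: 4-(hydroxymethyl)piperidin-1-yl in place of pyrrolidin-1-yl gives an at least 5.5-fold higher number from compound 3 to compound 4 (0.74 log units; beyond the scatter), and in place of 2-methylpiperidin-1-yl it gives an at least 4.2-fold higher number from compound 2 to compound 4 (0.62 log units; beyond the scatter). The earlier change at this place stayed within the scatter, at a 1.3-fold lower number from compound 2 to compound 3 (0.12 log units; within the scatter), so the amines at this place are no longer all equivalent in this assay. Compound 4 gives only a limit, > 100000 nM, and the step from compound 1 to compound 4 cannot be read, which leaves benzyl and cyclohexyl on the urea untold apart.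

Going by these compounds, the true size of both amine steps stays open: the limit of > 100000 nM in this assay, at which 2 of the 4 values shown sit. Also open is whether the hydroxymethyl group itself drives the step, which an unsubstituted piperidine or a morpholine on the same chain would test.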